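Trimming the Ring on the Core Nitrogen

A few compounds are considered here, and "the series" means these few. Any claim that something is new, unique, unknown or untested is made for them only; others in the source may bear on it.

Measured compounds:
Compound 1, `CC(C)c1onc(-c2c(Cl)cccc2Cl)c1COc1ccc(-c2nc3ccc(C(=O)O)cc3n2Cc2ccc(F)cc2)cc1`: 3.31 nM
Compound 2, `CC(=O)N1CCC(n2c(-c3ccc(OCc4c(-c5c(Cl)cccc5Cl)noc4C(C)C)cc3)nc3ccc(C(=O)O)cc32)CC1`: 1430 nM
Compound 3, `CC(C)c1onc(-c2c(Cl)cccc2Cl)c1COc1ccc(-c2nc3ccc(C(=O)O)cc3n2C2CCCCC2)cc1`: 4.21 nM

In an assay on Huh-7 cells for agonist activity at Bile acid receptor (Homo sapiens), read by a luciferase reporter (a lower number here means that less compound is needed, a higher number that more compound is needed for the effect), compound 3 stands second highest of the three numbers. Its nearest neighbour is compound 1: the step of a 1.3-fold higher number from compound 1 to compound 3 (0.10 log units; within the scatter) lies within the scatter. Its furthest is compound 2: the step of a 340-fold lower number from compound 2 to compound 3 (2.53 log units; beyond the scatter) is large. Compound 4, `CC(C)c1onc(-c2c(Cl)cccc2Cl)c1COc1ccc(-c2nc3ccc(C(=O)O)cc3n2C2CCCC2)cc1`, differs from compound 3 in one place: cyclopentyl in place of cyclohexyl on an aromatic nitrogen. Going by the values given here, no measured step touches a cyclopentyl. The closest guide is the swap to a plain carbon ring, a 1.3-fold higher number from compound 1 to compound 3 (0.10 log units; within the scatter), which barely moved the number, whereas the acetylpiperidinyl swap, a 340-fold lower number from compound 2 to compound 3 (2.53 log units; beyond the scatter), was large. Removing one carbon from a plain ring is expected to change little. Compound 4 is expected near 5 nM, between 1.5 nM and 15 nM. The expected step is a 1.2-fold higher number from compound 3 to compound 4 (0.07 log units; within the scatter), within the scatter.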

Compound 4, half-maximal effective concentration: 13.6 nM
Compound 4: middle estimate off by 2.7-fold (0.43 log units), on the low side, and the stated range covers the measured number.
By their numbers in this assay, from the lowest: compounds 1 and 3 (each within the scatter of the next); then compound 4; then compound 2.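

In this assay ring size on this nitrogen does count: going from the six-membered to the five-membered ring gives a 3.2-fold higher number from compound 3 to compound 4 (0.51 log units; beyond the scatter) and the comparison with 4-fluorobenzyl gives a 4.1-fold higher number from compound 1 to compound 4 (0.61 log units; beyond the scatter) so cyclopentyl parts from two groups that had matched within the scatter. Both steps remain modest beside a 110-fold lower number from compound 2 to compound 4 (2.02 log units; beyond the scatter) and that large gap still belongs to 1-acetylpiperidin-4-yl. Nothing available explains why the five-membered ring raises the number. Open, as far as these compounds go, is whether cyclobutyl would raise it further, and whether a plain piperidin-4-yl, without the acetyl, would restore the low numbers.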